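The source may report more compounds than this note shows. Statements on the series, on what has been measured and on what is new or still open speak of the compounds shown alone.

Notes on the series. Among the measured compounds shown here, compound 2 `C#CCOC(=O)/C(C)=C/CC/C(C)=C/CC/C(C)=C/CC[C@@H]1[C@@]2(C)CCC(=O)C(C)(C)[C@H]2CC[C@@]1(C)O` carries the ethynyl group on a saturated chain carbon bound to an oxygen next to a carbonyl group; in a functional assay on DU-145 cells (Homo sapiens) for antiproliferative activity, read by MTT assay, with a stated time of 48 h (on this read-out lower numbers stand for stronger inhibition and higher numbers for weaker inhibition), compound 2 gives 46100 nM, the only number in the set. Compound 1 `C/C(=C\CC/C(C)=C/CC[C@@H]1[C@@]2(C)CCC(=O)C(C)(C)[C@H]2CC[C@@]1(C)O)CC/C=C(\C)C(=O)OCc1cn(-c2ccc(F)c(Cl)c2)nn1` gives > 150000 nM in this assay, a limit of the assay and not a number. Compound 3 `COc1cccc(-n2cc(COC(=O)/C(C)=C/CC/C(C)=C/CC/C(C)=C/CC[C@@H]3[C@@]4(C)CCC(=O)C(C)(C)[C@H]4CC[C@@]3(C)O)nn2)c1` gives > 150000 nM, likewise a limit. For the measured compounds named here, the single step between measured compounds, a step that the two limits leave unreadable from compound 1 to compound 3, is unreadable due to the limit of > 150000 nM in this assay, at which 2 of the 3 values shown sit.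

Compound 4 `C/C(=C\CC/C(C)=C/CC[C@@H]1[C@@]2(C)CCC(=O)C(C)(C)[C@H]2CC[C@@]1(C)O)CC/C=C(\C)C(=O)OCc1cn(-c2ccc(C)cc2)nn1` is not yet measured; it differs from compound 2 thus: 1-(4-methylphenyl)-1H-1,2,3-triazol-4-yl in place of ethynyl on a saturated chain carbon bound to an oxygen next to a carbonyl group. Going by the values given here, no measured step reproduces this change, but both compounds that carry an aryl-substituted triazolyl group at that position, compound 1 and compound 3, return only a limit, so a loss in this assay beyond the scatter is expected for compound 4, with a good chance that the assay again reports only a limit. The step expected in this assay is a 4.3-fold higher number from compound 2 to compound 4 (0.64 log units; beyond the scatter). Compound 4 is estimated at 200000 nM, in the range 70000 nM to 600000 nM.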

Compound 4, half-maximal inhibitory concentration: > 150000 nM
Compound 4 ended at the assay's limit; the forecaster's own chance of this, stated with the estimate: 75%; the middle value is on the limit's open side.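

In this assay, among the compounds shown here, the change on a saturated chain carbon bound to an oxygen next to a carbonyl group now has a readable size, with 1-(4-methylphenyl)-1H-1,2,3-triazol-4-yl in place of ethynyl giving an at least 3.2-fold higher number from compound 2 to compound 4 (0.51 log units; beyond the scatter) as the first readable step at this position. The 4-methylphenyl group joins 3-chloro-4-fluorophenyl and 3-methoxyphenyl as a third aryl group on the triazolyl group that ends at the limit, and no compound shown goes against this. The steps among compound 1, compound 3 and compound 4 cannot be read, because all three sit at one limit: the limit of > 150000 nM in this assay, at which 3 of the 4 values shown sit.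

As far as these compounds go, it remains open whether the higher number follows from the triazolyl group itself or from its aryl group. A triazolyl group carrying a small amine or a carboxylic acid in place of the aryl group would separate the two.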